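The source may hold more compounds than are shown below. What is called first, only, known or untested is meant among the compounds shown, and "the series" means these compounds.

Of the compounds shown here, three with a shared core have been measured for how strongly they inhibit the enzyme in an assay on isolated protein for inhibition of 2-Hydroxyacid oxidase 2 (Rattus norvegicus), tested at 10 uM; a lower number here means a weaker effect, a higher number a stronger effect of the compound at the concentration tested. Compound 1 `Cc1n[nH]c(C(=O)O)c1Cc1ccccc1-c1ccc(F)cc1` gives 73%, compound 2 `Cc1nn(C)c(C(=O)O)c1Cc1cccc(-c2ccc(F)cc2)c1` gives 10%, and compound 3 `CNC(=O)c1[nH]nc(C)c1Cc1cccc(-c2ccc(F)cc2)c1` gives 53%. Compound 3 therefore stands second of the three: its number sits beyond the scatter below that of compound 1 and well beyond the scatter above that of compound 2.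

Compound 4 `Cc1n[nH]c(C(=O)NS(C)(=O)=O)c1Cc1cccc(-c2ccc(F)cc2)c1` is yet to be measured. It differs from compound 3 in one place: methylsulfonyl in place of methyl on an amide-type nitrogen. Among the compounds with values here, no measured pair shows this same change, so its effect is unknown. The step of a number 2 percentage points higher from compound 3 to compound 4 (within the scatter) is expected to be small, within the scatter. For compound 4 the estimate in this assay is 55%, with a range from 25% to 80%.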

Compound 4, a percentage reported as inhibition, at one concentration (the size of the read-out at that concentration, not a potency): 3%
Compound 4: the middle estimate sits 52 percentage points above what was measured; measured number below the stated range.
By their numbers in this assay, from the lowest: compounds 4 and 2 (each within the scatter of the next); then compound 3; then compound 1.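

On the amide-type nitrogen, methylsulfonyl in place of methyl gives a number 50 percentage points lower from compound 3 to compound 4 (beyond the scatter) in this assay. Within the data shown here, this position therefore does not accept every group, a point the earlier compounds could not settle, as none of them formed a one-place pair. Nothing measured here explains the drop. Still open, on these data alone, is what an ethyl or an acetyl on that nitrogen would give. A single change also cannot show whether the size of the new group or something else about the sulfonyl unit matters.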